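Swapping Benzyl for an Acetamidophenylethyl Group

The compounds below may be only part of what the source reports. "The series", "measured", "known", "first", "only" and "open" are said of these compounds alone.

Measured compounds:
Compound 1, `O=S(=O)(NCC1CCN(CCCc2c[nH]c3ccc(-n4cnnc4)cc23)CC1)c1ccccc1`: 73%
Compound 2, `c1ccc(CNCC2CCN(CCCc3c[nH]c4ccc(-n5cnnc5)cc34)CC2)cc1`: 101%

Both compounds share the same core and differ only in the group carried on an amine nitrogen. In a functional assay on CHO cells for activation of 5-hydroxytryptamine receptor 1D (Homo sapiens), read by GTPgammaS binding (a higher number here means a larger maximal response, a lower number a smaller maximal response), compound 1 gives 73%, while compound 2 gives 101%. Within the data shown here, the one measured step, a number 28 percentage points higher from compound 1 to compound 2 (beyond the scatter), shows that changing this group can move the maximal response. Compound 2 therefore stands highest of the two numbers, its nearest neighbour being compound 1, which sits clearly lower.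

Compound 3, `CC(=O)Nc1ccc([C@H](C)NCC2CCN(CCCc3c[nH]c4ccc(-n5cnnc5)cc34)CC2)cc1`, keeps the core of compound 2 and changes the same nitrogen again: 1-(4-acetamidophenyl)ethyl in place of benzyl on an amine nitrogen. The step from compound 1 to compound 2 is the only one that bears on this site, and it was a modest rise. Among the measured compounds shown here, no measured step shows what an acetamido group or the extra methyl on this chain does here, so the direction of any change is uncertain, and a response near that of compound 2 seems as likely as a small shift. Compound 3 is expected to give about 95%, within 75% to 112%, a step of a number 6 percentage points lower from compound 2 to compound 3 (within the scatter) that is estimated to stay within the usual scatter.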

Compound 3, largest response reached (reported as efficacy), in percent of the reference or control that the assay uses: 99%
Estimate against measurement, compound 3: 4 percentage points below; measured number inside the range.
By their numbers in this assay, from the lowest: compound 1; then compounds 3 and 2 (each within the scatter of the next).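

Putting 1-(4-acetamidophenyl)ethyl in place of benzyl on this amine nitrogen brings more heavy atoms, a hydrogen-bond donor and acceptor, and a defined stereocentre, yet the maximal response in this assay shows no change that can be told from scatter (a number 2 percentage points lower from compound 2 to compound 3 (within the scatter)). This position therefore tolerates a clearly larger group than benzyl, at least for this one example, which the earlier pair of compounds could not show. The rise seen against the phenylsulfonyl group also holds with the new group (a number 26 percentage points higher from compound 1 to compound 3 (beyond the scatter)), so compound 2 and compound 3 both stand apart from compound 1, while nothing available explains why the response holds.

The new group differs from benzyl in several features at once, so these compounds cannot separate what the acetamido group, the added methyl and the stereocentre each contribute, nor show whether the mirror-image form behaves alike. Going by these compounds, it also remains open how far this tolerance extends, for instance to a carboxylic acid or a basic amine on the aromatic ring, or to a longer chain between that ring and the amine nitrogen.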